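Three aryl variants measured, propyl chain next

This account rests on a few compounds, and the source may have more. Where it says the series, first, only, none or still open, it means among the compounds named here.

Compound 1 `CC(=O)OC[C@H]1O[C@@H](n2cc(CN3C(=O)/C(=C/c4ccc(N(C)C)cc4)c4ccccc43)nn2)[C@H](OC(C)=O)[C@@H](OC(C)=O)[C@@H]1OC(C)=O` gives 25200 nM in a functional assay on MCF7 cells (Homo sapiens) for cytotoxicity, read by sulforhodamine B assay, with a stated time of 48 h; on this read-out higher numbers stand for weaker inhibition and lower numbers for stronger inhibition.
Compound 2 `CC(=O)OC[C@H]1O[C@@H](n2cc(CN3C(=O)/C(=C/c4ccc5ccccc5c4)c4ccccc43)nn2)[C@H](OC(C)=O)[C@@H](OC(C)=O)[C@@H]1OC(C)=O` gives 32700 nM in this assay.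
Compound 3 `CC(=O)OC[C@H]1O[C@@H](n2cc(CN3C(=O)/C(=C/c4ccco4)c4ccccc43)nn2)[C@H](OC(C)=O)[C@@H](OC(C)=O)[C@@H]1OC(C)=O` gives 29100 nM in this assay.

Compound 3 holds the second highest of the three numbers; its nearest neighbour is compound 2, its furthest compound 1, and both gaps lie within the scatter. The three measured steps all exchange the group on the double-bonded chain carbon: a 1.3-fold higher number from compound 1 to compound 2 (0.11 log units; within the scatter), a 1.2-fold higher number from compound 1 to compound 3 (0.06 log units; within the scatter) and a 1.1-fold lower number from compound 2 to compound 3 (0.05 log units; within the scatter), every one within the scatter. Compound 4 `CCC/C=C1/C(=O)N(Cc2cn([C@@H]3O[C@H](COC(C)=O)[C@@H](OC(C)=O)[C@H](OC(C)=O)[C@H]3OC(C)=O)nn2)c2ccccc21` is unmeasured; it differs from compound 3 by propyl in place of furan-2-yl on a double-bonded chain carbon bound to a double-bonded ring carbon. Each measured step exchanged one ring for another at this place with no effect beyond the scatter, so the same place is addressed here, although no chain without a ring has been measured. The expectation is therefore a step of a 1.0-fold higher number from compound 3 to compound 4 (0.01 log units; within the scatter) in this assay, none beyond the scatter. The estimate for compound 4 is 30000 nM, expected within 14000 nM to 65000 nM.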

Compound 4, half-maximal inhibitory concentration: 22600 nM
Beside the measured number, compound 4's estimate is 1.3-fold (0.12 log units) above it, within the range that was stated.
By their numbers in this assay, from the lowest: compounds 4, 1, 3 and 2 (each within the scatter of the next).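

In this assay the place on a double-bonded chain carbon bound to a double-bonded ring carbon now carries a chain with no ring, and the change stays within the scatter against all three ring-bearing compounds: a 1.3-fold lower number from compound 3 to compound 4 (0.11 log units; within the scatter) and a 1.4-fold lower number from compound 2 to compound 4 (0.16 log units; within the scatter) and also a 1.1-fold lower number from compound 1 to compound 4 (0.05 log units; within the scatter). Across compounds 1 to 4, therefore, a ring at this place is not needed to keep the number at this level, and propyl, with no hydrogen-bond acceptor, gives a number within the scatter of the furan-2-yl compound 3. No available evidence explains this insensitivity to the group at this place.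

As far as these compounds go, it remains open whether a carboxylic acid, a primary amine or a longer chain such as octyl at this place would move the number beyond the scatter. Also open, from the compounds shown here alone, is whether replacing the acetyl groups on the shared core with free hydroxyl groups would do so.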